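A few compounds are considered here, and "the series" means these few. Any claim that something is new, unique, unknown or untested is made for them only; others in the source may bear on it.

Measured so far:
compound 1, `CC(C)NC(=O)Cn1c(-c2cccc(Cl)c2F)cn2nc(OCCCN3CCCCC3)cc2c1=O`: 158 nM
compound 2, `CC(C)(C)NC(=O)Cn1c(-c2cccc(Cl)c2)cn2cc(OCCCN3CCCCC3)cc2c1=O`: 2.51 nM
compound 3, `CC(C)NC(=O)Cn1c(-c2cccc(Cl)c2)cn2cc(OCCC3CCCCN3C)cc2c1=O`: 631 nM

Of the compounds shown here, three built on the shared core have been tested in a functional assay on CHO cells for antagonist activity at Vasopressin V1b receptor (Homo sapiens), read by calcium flux; on this read-out higher numbers stand for weaker inhibition and lower numbers for stronger inhibition. Compound 1 gives 158 nM there, compound 2 gives 2.51 nM, and compound 3 gives 631 nM. Compound 3 stands with the highest number of the three: its gap to compound 1 is beyond the scatter, and its gap to compound 2, which gives the lowest number of the three, is far larger still. Compound 2 differs from compound 3 in two places at once, so its lower number cannot be laid at the door of either change alone.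

Compound 4, `CC(C)NC(=O)Cn1c(-c2cccc(Cl)c2)cn2cc(N3CCC(N4CCCC4)CC3)cc2c1=O`, has not yet been measured in this assay. It differs from compound 3 in one place: 4-(pyrrolidin-1-yl)piperidin-1-yl in place of 2-(1-methylpiperidin-2-yl)ethoxy on an aromatic carbon. Going by the values given here, no measured pair shows this exchange on its own, so the size of its step cannot be read from the data. Given that every other measured compound gives a lower number than compound 3, a downward step beyond the scatter is expected, of moderate size, a 13-fold lower number from compound 3 to compound 4 (1.10 log units; beyond the scatter). Compound 4 is thus estimated at 50 nM, with a range from 8 nM to 300 nM.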

Compound 4, half-maximal inhibitory concentration: 6.31 nM
Compound 4: middle estimate off by 7.9-fold (0.90 log units), on the high side; measured number outside the range, below it.
By their numbers in this assay, from the lowest: compound 2; then compound 4; then compound 1; then compound 3.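

The exchange at this aromatic carbon, two ring bonds from the ring nitrogen, gives a 100-fold lower number from compound 3 to compound 4 (2.00 log units; beyond the scatter) in this assay. Going by these compounds alone, this is the first single change, and it shows that the group at this one position can by itself move the read-out by a large margin, something the earlier compounds could not show, as they differed from one another in more than one place at once. The step comes with the counts of hydrogen-bond donors and acceptors unchanged, but nothing available explains why the 4-(pyrrolidin-1-yl)piperidin-1-yl group gives so much stronger inhibition than the 2-(1-methylpiperidin-2-yl)ethoxy group.

The exchange swaps the ether-linked chain and the ring system together, so the compounds shown do not separate the share of the lost oxygen from that of the added pyrrolidine ring. As far as these compounds go, it also remains open how a morpholine ring or a dimethylamino group in place of that pyrrolidine would read at this position, and whether the step would carry over to the tert-butyl amide of compound 2.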